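Benzyl in place of methyl on the double-bonded nitrogen

The source may report more compounds than this note shows. Statements on the series, on what has been measured and on what is new or still open speak of the compounds shown alone.

Compound 1 `C/N=C(\S)OC[C@H]1OC(n2cnc3c(NC4CCOC4)ncnc32)[C@H](O)[C@@H]1O` is the reference point of this set. In an assay on DDT1 cells (Cricetulus griseus) for binding affinity to adenosine receptor A1 (Homo sapiens), read by radioligand binding (on this read-out higher numbers stand for weaker inhibition and lower numbers for stronger inhibition), compound 1 gives 45 nM, the lowest of the three numbers measured. Compound 2 `CCNC(=O)OC[C@H]1OC(n2cnc3c(NC4CCOC4)ncnc32)[C@H](O)[C@@H]1O` gives 167 nM in this assay, and compound 3 `O[C@@H]1[C@@H](CO/C(S)=N/C2CCCCC2)OC(n2cnc3c(NC4CCOC4)ncnc32)[C@@H]1O` gives 253 nM. Both departures from compound 1 weaken binding: a 3.7-fold higher number from compound 1 to compound 2 (0.57 log units; beyond the scatter) and a 5.6-fold higher number from compound 1 to compound 3 (0.75 log units; beyond the scatter). Between the two weaker compounds the gap is small: a 1.5-fold higher number from compound 2 to compound 3 (0.18 log units; within the scatter).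

Compound 4 `O[C@@H]1[C@@H](CO/C(S)=N/Cc2ccccc2)OC(n2cnc3c(NC4CCOC4)ncnc32)[C@@H]1O` differs from compound 1 by phenyl in place of hydrogen on a saturated chain carbon bound to a double-bonded nitrogen. The measured step that bears on this is the one with cyclohexyl in place of methyl on a double-bonded nitrogen, a 5.6-fold higher number from compound 1 to compound 3 (0.75 log units; beyond the scatter), where enlarging the group on that nitrogen raised the number by a modest amount. Benzyl is likewise a larger group than methyl in that position, so a step of similar kind is expected, in the direction of a higher number, likely beyond the scatter but not large. The expected step from compound 1 is a 3.3-fold higher number from compound 1 to compound 4 (0.52 log units; beyond the scatter). For compound 4 the estimate in this assay is 150 nM, with a range from 50 nM to 450 nM.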

Compound 4, inhibition constant: 12 nM
Compound 4: middle estimate off by 13-fold (1.10 log units), on the high side, and the stated range ends above it.
By their numbers in this assay, from the lowest: compound 4; then compound 1; then compounds 2 and 3 (each within the scatter of the next).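

On the double-bonded nitrogen, a larger group does not by itself raise the number in this assay: methyl to benzyl gives a 3.8-fold lower number from compound 1 to compound 4 (0.57 log units; beyond the scatter), whereas cyclohexyl in place of methyl had given a higher number, and benzyl in place of cyclohexyl gives a 21-fold lower number from compound 3 to compound 4 (1.32 log units; beyond the scatter). The benzyl group also stands well clear of the group carried by compound 2, with a 14-fold lower number from compound 2 to compound 4 (1.14 log units; beyond the scatter), so this position tolerates a ring and the kind of ring matters. Nothing shown accounts for the difference between benzyl and cyclohexyl.

As far as these compounds go, it remains open whether the lower number belongs to the aromatic ring itself or to its spacing from the nitrogen. Phenyl directly on the nitrogen, phenylethyl and pyridylmethyl would each separate these readings.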